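Removing one chloro from the dichlorophenyl of compound 3

This account rests on a few compounds, and the source may have more. Where it says the series, first, only, none or still open, it means among the compounds named here.

Compound 1 `O=C([C@@H]1C[C@H](N2CCN(c3ccc(Cl)cn3)CC2)CN1)N1CCSC1` in an assay on a cell-free system (plasma) for inhibition of Dipeptidyl peptidase 4 (Rattus norvegicus), read by fluorescence (on this read-out lower numbers stand for stronger inhibition and higher numbers for weaker inhibition), gives 3.1 nM.
Compound 2 `O=C([C@@H]1C[C@H](N2CCN(c3cccc(Cl)c3)CC2)CN1)N1CCSC1` gives 7.2 nM.
Compound 3 `O=C([C@@H]1C[C@H](N2CCN(c3ccc(Cl)c(Cl)c3)CC2)CN1)N1CCSC1` gives 4.2 nM.

Compound 3 holds the second highest of the three numbers; its nearest neighbour is compound 1 a 1.4-fold higher number from compound 1 to compound 3 (0.13 log units; within the scatter), and the step of a 1.7-fold lower number from compound 2 to compound 3 (0.23 log units; within the scatter) also lies within the scatter. Compound 4 `O=C([C@@H]1C[C@H](N2CCN(c3ccc(Cl)cc3)CC2)CN1)N1CCSC1` differs from compound 3 by hydrogen in place of chloro on an aromatic carbon. Among the compounds with values here, no measured step removes exactly this chloro; the closest guide is a 1.7-fold lower number from compound 2 to compound 3 (0.23 log units; within the scatter), a change of a chloro on the same ring that stayed within the scatter, while a 2.3-fold higher number from compound 1 to compound 2 (0.37 log units; beyond the scatter) was only modest. A step of no more than the scatter is therefore expected for a 1.3-fold higher number from compound 3 to compound 4 (0.12 log units; within the scatter), with no clear direction. Compound 4 is estimated at 5.5 nM, in the range 2.5 nM to 12 nM.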

Compound 4, half-maximal inhibitory concentration: 10.3 nM
Estimate against measurement, compound 4: 1.9-fold (0.27 log units) below; low and high end bracket the measured number.
By their numbers in this assay, from the lowest: compounds 1, 3, 2 and 4 (each within the scatter of the next, the first and the last beyond it).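

Going from 3,4-dichlorophenyl to 4-chlorophenyl (a 2.5-fold higher number from compound 3 to compound 4 (0.39 log units; beyond the scatter)) gives the first step that removes a chloro from this ring and lies beyond the scatter, though it is modest. The 3-chlorophenyl and 4-chlorophenyl groups cannot be told apart (a 1.4-fold higher number from compound 2 to compound 4 (0.16 log units; within the scatter)), while 4-chlorophenyl and 5-chloropyridin-2-yl can (a 3.3-fold higher number from compound 1 to compound 4 (0.52 log units; beyond the scatter)). On these data alone, it remains open whether a fluoro, methoxy or nitrile in place of the chloro on this aromatic carbon would give a similar step. No evidence is available to explain these steps.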